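Swapping propyl for propylamino on the carbonyl carbon

The source may report more compounds than this note shows. Statements on the series, on what has been measured and on what is new or still open speak of the compounds shown alone.

Compound 1 `CCCC(=O)Nc1ccc(S(=O)(=O)Oc2ccccc2C(C)C)cc1` gives the lowest of the three numbers measured in a functional assay on HT-29 cells (Homo sapiens) for antiproliferative activity, read by sulforhodamine B assay, with a stated time of 48 h (on this read-out lower numbers stand for stronger inhibition and higher numbers for weaker inhibition), at 4900 nM. Compound 2 `CCCC(=O)Nc1ccc(S(=O)(=O)Oc2ccccc2I)cc1` gives 11000 nM, and compound 3 `CC(C)(C)C(=O)Nc1ccc(S(=O)(=O)Oc2ccccc2I)cc1` gives 9500 nM. The step of a 2.2-fold higher number from compound 1 to compound 2 (0.35 log units; beyond the scatter) lies beyond the scatter, whereas the step of a 1.2-fold lower number from compound 2 to compound 3 (0.06 log units; within the scatter) does not, and the gap between compound 1 and compound 3 also stays within the scatter.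

Compound 4 `CCCNC(=O)Nc1ccc(S(=O)(=O)Oc2ccccc2C(C)C)cc1` differs from compound 1 in one place: propylamino in place of propyl on a carbonyl carbon. Among the compounds with values here, no measured step alters that spot in the same way; the nearest, a 1.2-fold lower number from compound 2 to compound 3 (0.06 log units; within the scatter), changed only the group on the carbonyl carbon and stayed within the scatter. A step of about that size, in no firm direction, is therefore expected in this assay, namely a 1.1-fold higher number from compound 1 to compound 4 (0.05 log units; within the scatter). Compound 4 is expected to give 5500 nM, between 2200 nM and 14000 nM.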

Compound 4, half-maximal inhibitory concentration: 6300 nM
For compound 4 the middle estimate is 1.1-fold (0.06 log units) below the measured one; the measured number falls inside the stated range.
By their numbers in this assay, from the lowest: compounds 1, 4, 3 and 2 (each within the scatter of the next, the first and the last beyond it).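

Putting propylamino in place of propyl on the carbonyl carbon adds a nitrogen and a hydrogen-bond donor, and in this assay this gives a 1.3-fold higher number from compound 1 to compound 4 (0.11 log units; within the scatter), so the two numbers cannot be told apart. Until now this spot had seen only a swap of one carbon group for another, so this is its first change that brings in a nitrogen, and it too stays within the scatter. Nothing measured here explains why the numbers stay so close. From the compounds shown here alone, whether a longer chain or a carboxylic acid in place of propylamino on the carbonyl carbon would move the number remains open. So does whether propylamino behaves alike when iodo replaces isopropyl.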